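The compounds below may be only part of what the source reports. "The series", "measured", "known", "first", "only" and "open" are said of these compounds alone.

In a functional assay on HL-60 cells (Homo sapiens) for cytotoxicity, read by WST assay, with a stated time of 48 h (on this read-out lower numbers stand for stronger inhibition and higher numbers for weaker inhibition), compound 1 `Oc1ccc(/C=C/C[C@H]2C[C@@H]([C@@H](O)c3ccccc3)CO[C@@H]2c2ccccc2)cc1` gives 7380 nM, compound 2 `COc1ccccc1/C=C/C[C@H]1C[C@@H]([C@@H](O)c2ccccc2)CO[C@@H]1c1ccccc1` gives 10100 nM and compound 3 `Cc1ccc(/C=C/C[C@H]2C[C@@H]([C@@H](O)c3ccccc3)CO[C@@H]2c2ccccc2)cc1C` gives 9880 nM, which leaves compound 3 level with the other two, all within the scatter. The next change leads to compound 4 `O[C@@H](c1ccccc1)[C@H]1CO[C@H](c2ccccc2)[C@@H](C/C=C/c2cccnc2)C1`: pyridin-3-yl in place of 3,4-dimethylphenyl on a double-bonded chain carbon bound to a double-bonded chain carbon. The swaps at this same place bear on it: a 1.3-fold higher number from compound 1 to compound 3 (0.13 log units; within the scatter), a 1.0-fold lower number from compound 2 to compound 3 (0.01 log units; within the scatter) and a 1.4-fold higher number from compound 1 to compound 2 (0.14 log units; within the scatter), each within the scatter. None of them brings in a ring with a hetero atom, so the data do not cover that feature directly. No shift beyond the scatter is therefore expected in this assay. The expected step is a 1.1-fold higher number from compound 3 to compound 4 (0.05 log units; within the scatter). Compound 4 is estimated at 11000 nM, with an expected range of 5000 nM to 25000 nM.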

Compound 4, half-maximal inhibitory concentration: > 100000 nM
Compound 4 ended at the assay's limit; the forecaster's own chance of this, stated with the estimate: 15%; middle value at least 9.0-fold (0.95 log units) away from the limit.
By their numbers in this assay, from the lowest: compounds 1, 3 and 2 (each within the scatter of the next). At a limit, above all of these: compound 4.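

Across the 4-hydroxyphenyl, 2-methoxyphenyl and 3,4-dimethylphenyl groups, this place on a double-bonded chain carbon bound to a double-bonded chain carbon had shown no shift beyond the scatter in this assay, but pyridin-3-yl gives an at least 10-fold higher number from compound 3 to compound 4 (1.00 log units; beyond the scatter), an at least 9.9-fold higher number from compound 2 to compound 4 (0.99 log units; beyond the scatter) and an at least 13-fold higher number from compound 1 to compound 4 (1.13 log units; beyond the scatter). Among the compounds shown, only compound 4 carries a ring with a hetero atom, so the place is sensitive to at least this one ring change. Compound 4 stands at a limit of the assay, not at a number: the limit of > 100000 nM in this assay, at which 1 of the 4 values shown sits.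

On these data alone, how far compound 4 lies past that limit stays open. Also open, as far as these compounds go, is whether a thienyl ring, a pyrimidinyl ring or an aminophenyl group here would track pyridin-3-yl or the three phenyl groups.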